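The compounds below may be only part of what the source reports. "The series", "measured", "known", "first", "only" and "open" are said of these compounds alone.

Measured in a functional assay on A549 cells (Homo sapiens) for antiproliferative activity, read by MTT assay, with a stated time of 72 h; on this read-out higher numbers stand for weaker inhibition and lower numbers for stronger inhibition:
- Compound 1 `COc1cc2ncnc(Nc3ccc(Cl)c(C(F)(F)F)c3)c2cc1OCCCN1CCNCCNCCNCC1`: 5350 nM
- Compound 2 `COc1cc2ncnc(Nc3ccc(Br)cc3F)c2cc1OCCCN1CCNCCNCC1`: 16100 nM
- Compound 3 `COc1cc2ncnc(Nc3ccc(Cl)c(C(F)(F)F)c3)c2cc1OCCCN1CCNCCNCC1`: 6230 nM

Compound 3 is not separated from the larger-ring analogue, the step being a 1.2-fold higher number from compound 1 to compound 3 (0.07 log units; within the scatter), and only compound 2 stands apart with its higher number. Compound 4 `COc1cc2ncnc(Nc3ccc(Cl)cc3Cl)c2cc1OCCCN1CCNCCNCC1` keeps the nine-membered ring of compound 3 and differs from it as follows: 2,4-dichlorophenyl in place of 4-chloro-3-(trifluoromethyl)phenyl on a nitrogen on an aromatic ring. It has 2,4-dichlorophenyl in place of 4-chloro-3-(trifluoromethyl)phenyl on a nitrogen on an aromatic ring. The ring step does not bear on this change. The nearest guide is the modest 2.6-fold lower number from compound 2 to compound 3 (0.41 log units; beyond the scatter), where 4-bromo-2-fluorophenyl, also carrying only halogens, gave the weaker result. In this assay a partial move toward compound 2 is therefore expected, an expected step of a 1.6-fold higher number from compound 3 to compound 4 (0.21 log units; within the scatter). The estimate for compound 4 is 10000 nM, with an expected range of 4500 nM to 22000 nM.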

Compound 4, half-maximal inhibitory concentration: 44200 nM
The estimate for compound 4 lay 4.4-fold (0.65 log units) below the measured number; measured number outside the range, above it.
By their numbers in this assay, from the lowest: compounds 1 and 3 (each within the scatter of the next); then compound 2; then compound 4.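

Among the compounds shown here, the aryl group on the nitrogen matters more than the earlier compounds showed: replacing 4-chloro-3-(trifluoromethyl)phenyl with 2,4-dichlorophenyl gives a 7.1-fold higher number from compound 3 to compound 4 (0.85 log units; beyond the scatter), far larger than the ring step. Carrying only halogens does not place a group at one level either, since the two halogen-only groups are separated by a 2.7-fold higher number from compound 2 to compound 4 (0.44 log units; beyond the scatter). Nothing available explains the size of these steps. Still open, going by these compounds, is how a plain phenyl or a phenyl bearing a nitrile would stand at this position, and whether 2,4-dichlorophenyl behaves the same way on the larger ring of compound 1.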